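The source may hold more compounds than are shown below. What is called first, only, known or untested is meant among the compounds shown, and "the series" means these compounds.

Compound 1 `COc1cc(Oc2cccc(Nc3ccccc3)c2)cc(OC)c1CNCc1ccccc1` and compound 2 `COc1cc(Oc2cccc(Nc3ccccc3)c2)cc(OC)c1CN[C@H](C)c1ccccc1` share one core and differ only in a methyl in place of hydrogen on a saturated chain carbon bound to an amine nitrogen and an aromatic carbon. In a functional assay on HT-29 cells (Homo sapiens) for inhibition, read by MTT assay, with a stated time of 72 h (a higher number here means a weaker inhibitor, a lower number a stronger inhibitor), compound 1 gives 3340 nM, while compound 2 gives 5120 nM; the step of a 1.5-fold higher number from compound 1 to compound 2 (0.19 log units; within the scatter) is within the scatter. Compound 2 thus carries the highest of the two numbers, yet its nearest neighbour, compound 1, sits within the scatter of it, so no order between them can be claimed.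

Compound 3 `COc1cc(Oc2cccc(Nc3ccccc3)c2)cc(OC)c1CNC1CC1` is the next compound, differing from compound 2 by cyclopropyl in place of 1-phenylethyl on an amine nitrogen. Among the compounds with values here, only one measured step bears on this change, and it concerned a methyl rather than the removal of a six-membered aromatic ring; it was small. Within the data shown here, with no step of comparable kind in hand, the expectation for compound 3 in this assay is a number near that of compound 2, with a wide range, and the expected step of a 1.1-fold lower number from compound 2 to compound 3 (0.06 log units; within the scatter) is not beyond the scatter. Compound 3 is therefore estimated at 4500 nM, between 1500 nM and 13000 nM.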

Compound 3, half-maximal inhibitory concentration: 12300 nM
Beside the measured number, compound 3's estimate is 2.7-fold (0.44 log units) below it; measured number inside the range.
By their numbers in this assay, from the lowest: compounds 1 and 2 (each within the scatter of the next); then compound 3.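

The earlier pair showed only that adding a methyl on the saturated chain carbon stays within the scatter, whereas exchanging the whole group on the amine nitrogen does move the number. In this assay, cyclopropyl in place of 1-phenylethyl gives a 2.4-fold higher number from compound 2 to compound 3 (0.38 log units; beyond the scatter), and cyclopropyl in place of benzyl gives a 3.7-fold higher number from compound 1 to compound 3 (0.57 log units; beyond the scatter), so both steps run the same way and compound 3 is the weaker inhibitor against each of the other two. No measurement at hand bears on why the number rises.

Going by these compounds, it remains open whether the six-membered aromatic ring itself counts or only the size of the group on that nitrogen, a question that cyclohexyl or a longer chain such as n-butyl would address. On these data alone, how the opposite configuration of 1-phenylethyl would read also remains open.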